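This account rests on a few compounds, and the source may have more. Where it says the series, first, only, none or still open, it means among the compounds named here.

Compound 1 `c1ccc2c(c1)CC(c1nc3ccc(-c4cn[nH]c4)cc3[nH]1)CO2` gives 27 nM in an assay on isolated protein for inhibition of Rho-associated protein kinase 2 (Homo sapiens); on this read-out higher numbers stand for weaker inhibition and lower numbers for stronger inhibition. Among the three measured compounds this is the second highest number: compound 3 `Cc1[nH]ncc1-c1ccc2nc(C3COc4ccccc4C3)oc2c1` sits lower at 9 nM, while compound 2 `CC(C)Oc1ccc2c(c1)CC(c1nc3ccc(-c4ccnc(N)n4)cc3[nH]1)CO2` sits far higher at 296 nM.

Compound 4 `c1ccc2c(c1)CC(c1nc3ccc(-c4ccncc4)cc3[nH]1)CO2` differs from compound 1 in one place: pyridin-4-yl in place of 1H-pyrazol-4-yl on an aromatic carbon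

For the measured compounds named here, no measured pair shows this same change, so the expected effect rests on the scale seen among the three numbers. Compound 4 is expected to move somewhat toward weaker inhibition, with a step of a 2.6-fold higher number from compound 1 to compound 4 (0.41 log units; beyond the scatter) from compound 1 that goes beyond the scatter but stays well short of the gap to compound 2. Compound 4 is therefore estimated at 70 nM, within a range of 18 nM to 280 nM.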

Compound 4, half-maximal inhibitory concentration: 2 nM
For compound 4 the middle estimate is 35-fold (1.54 log units) above the measured one; measured number below the stated range.
By their numbers in this assay, from the lowest: compound 4; then compound 3; then compound 1; then compound 2.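

In this assay, pyridin-4-yl in place of 1H-pyrazol-4-yl on the shared core gives a 14-fold lower number from compound 1 to compound 4 (1.13 log units; beyond the scatter), a large step toward stronger inhibition. The position therefore accepts a six-membered aromatic ring, and in this pair strong inhibition does not depend on the hydrogen-bond donor that 1H-pyrazol-4-yl carries. Nothing available explains the size of this step. The compounds shown leave open whether the ring nitrogen and its placing matter, which a phenyl or pyridin-3-yl group at this position would test.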